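Swapping methylsulfonyl for chloro on a shared core

This account rests on a few compounds, and the source may have more. Where it says the series, first, only, none or still open, it means among the compounds named here.

Of the compounds shown here, three built on one shared core have been measured in a functional assay on MCF7 cells (Homo sapiens) for antiproliferative activity, read by MTT assay, with a stated time of 48 h; on this read-out lower numbers stand for stronger inhibition and higher numbers for weaker inhibition. Compound 1 `CS(=O)(=O)c1ccc(Nc2ncc(F)c(Nc3nc4ccccc4s3)n2)cc1` gives 6880 nM. Compound 2 `Cc1cnc(Nc2ccc(S(C)(=O)=O)cc2)nc1Nc1nc2ccc(Cl)cc2s1` gives 4320 nM. Compound 3 `Cc1cnc(Nc2ccc(S(C)(=O)=O)cc2)nc1Nc1nc2ccccc2s1` gives 6550 nM, the second highest of the three numbers; the step of a 1.1-fold lower number from compound 1 to compound 3 (0.02 log units; within the scatter) is within the scatter, and so is a 1.5-fold higher number from compound 2 to compound 3 (0.18 log units; within the scatter), so the three numbers cannot be told apart with confidence.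

Compound 4 `Cc1cnc(Nc2ccc(Cl)cc2)nc1Nc1nc2ccccc2s1` differs from compound 3 by chloro in place of methylsulfonyl on an aromatic carbon. Neither of the measured steps bears on this change: one swaps methyl for fluoro and the other removes a chloro, each on a different part of the molecule, and both leave the methylsulfonyl untouched. Both of those steps stayed within the scatter. Within the data shown here, there is thus no measured guide to what the loss of the methylsulfonyl does, and the only anchor is the number for compound 3. Compound 4 is expected to show a step of a 1.2-fold higher number from compound 3 to compound 4 (0.09 log units; within the scatter) in this assay, small and uncertain in direction. Compound 4 is therefore estimated at 8000 nM, with a range from 2500 nM to 26000 nM.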

Compound 4, half-maximal inhibitory concentration: > 50000 nM
Compound 4 ended at the assay's limit; the forecaster's own chance of this, stated with the estimate: 15%; at least 6.2-fold (0.79 log units) between middle value and limit.
By their numbers in this assay, from the lowest: compounds 2, 3 and 1 (each within the scatter of the next). At a limit, above all of these: compound 4.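

In this assay, among these compounds, chloro in place of methylsulfonyl on the aromatic carbon para to a large group gives an at least 7.6-fold higher number from compound 3 to compound 4 (0.88 log units; beyond the scatter), the only step so far that lies beyond the scatter. The earlier steps, on other parts of the molecule, left the numbers within the scatter of each other, so this position is the only place among the compounds shown where a change has moved the number clearly, and all three compounds that give a measured number keep the methylsulfonyl. The value of compound 4 is a limit and not a number, so the step has a lower bound but no known size: the limit of > 50000 nM in this assay, at which 1 of the 4 values shown sits.

What the compounds shown leave open is whether the methylsulfonyl itself is required, or whether another group at this position, such as a sulfonamide, an amine or a carboxylic acid, would leave the number where compound 3 stands, at 6550 nM. Also open, as far as these compounds go, is whether the same swap would have the same outcome on the cores of compound 1 and compound 2, each of which differs from compound 3 in one other place.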